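Enlarging the nitrogen group of compound 2

The source may hold more compounds than are shown below. What is called first, only, known or untested is meant among the compounds shown, and "the series" means these compounds.

Values in a functional assay for inhibition, with Rattus norvegicus as the target; a higher number here means a weaker inhibitor, a lower number a stronger inhibitor:
Compound 1 `CC(/N=c1\c(O)c(O)\c1=N/c1ccc(C#N)cc1)C(C)(C)C`: 520 nM
Compound 2 `CC(C)/N=c1\c(O)c(O)\c1=N/c1ccc(C#N)cc1`: 13700 nM
Compound 3 `N#Cc1ccc(Nc2c(NCc3ccccc3)c(=O)c2=O)cc1`: > 30000 nM

Compound 2 has the higher of the two actual numbers (13700 nM) and its nearest neighbour is compound 1 (520 nM) on this scale. The entry for compound 3 is only a limit. Compound 4 `C[C@H](/N=c1\c(O)c(O)\c1=N/c1ccc(C#N)cc1)C1CCCCC1` has not yet been measured. It has 1-cyclohexylethyl in place of isopropyl on a double-bonded nitrogen and keeps the rest of compound 2 unchanged. Going by the values given here, only one measured step bears on this swap, and it is large. Going by compound 1 and that step (a 26-fold higher number from compound 1 to compound 2 (1.42 log units; beyond the scatter)) with methyl in place of tert-butyl, a step of similar size towards a lower number, meaning a stronger inhibitor, is expected in this assay for compound 4 with its larger group. One pair shows no general rule, so this expectation stays loose. The expected change is a 23-fold lower number from compound 2 to compound 4 (1.36 log units; beyond the scatter) as estimated here. Compound 4 is estimated at 600 nM with a range of 120 nM to 3000 nM as the expected bounds.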

Compound 4, half-maximal inhibitory concentration: > 30000 nM
Compound 4: a limit, no number; the forecaster's own chance of this, stated with the estimate: 5%; middle value at least 50-fold (1.69 log units) away from the limit.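

Going from isopropyl to 1-cyclohexylethyl gives an at least 2.1-fold higher number from compound 2 to compound 4 (0.34 log units; beyond the scatter) in this assay, so a larger group on this nitrogen does not by itself give a stronger inhibitor. Putting 1-cyclohexylethyl in place of 1,2,2-trimethylpropyl gives an at least 57-fold higher number from compound 1 to compound 4 (1.76 log units; beyond the scatter), which shows that the kind of group at this place matters, not only its number of carbons. The entry for compound 4 is a limit and not a number: the limit of > 30000 nM in this assay, at which 2 of the 4 values shown sit.

Going by these compounds, how much weaker compound 4 really is therefore stays open, and both steps give only a minimum size. A plain cyclohexyl group, a straight butyl chain or the mirror-image form of 1-cyclohexylethyl on this nitrogen could help show whether the ring, the chain shape or the defined stereocentre goes with the loss.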